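The source may hold more compounds than are shown below. What is called first, only, known or untested is meant among the compounds shown, and "the series" means these compounds.

Measured compounds in a functional assay on SF-268 cells (Homo sapiens) for cytotoxicity, read by sulforhodamine B assay, with a stated time of 48 h; a lower number here means a stronger inhibitor of growth, a higher number a weaker inhibitor of growth:
compound 1, `CC1=C(C(=O)Nc2ccc(Cl)c(Cl)c2)C(c2cccc(Oc3ccccc3)c2)NC(=S)N1`: 6170 nM
compound 2, `COc1cccc(C2NC(=S)NC(C)=C2C(=O)Nc2ccc(Cl)c(Cl)c2)c1`: 12600 nM
compound 3, `CC1=C(C(=O)Nc2ccc(Cl)c(Cl)c2)C(c2cccc(Cl)c2)NC(=O)N1`: 11200 nM

Compound 3 holds the second highest of the three numbers, with compound 2 within the scatter and compound 1 also within the scatter. Compound 4, `CC1=C(C(=O)Nc2ccc(Cl)c(Cl)c2)C(c2ccccc2O)NC(=O)N1`, differs from compound 3 in one place: 2-hydroxyphenyl in place of 3-chlorophenyl on a saturated ring carbon. Among the measured compounds shown here, the only measured step, a 2.0-fold higher number from compound 1 to compound 2 (0.31 log units; beyond the scatter), also alters the aryl group on the saturated ring carbon and was modest; no step exchanges a chlorine for a hydroxyl, so that step bears only loosely here. An estimated step of a 1.0-fold lower number from compound 3 to compound 4 (0.01 log units; within the scatter) is therefore expected, not beyond the scatter. Compound 4 is estimated at 11000 nM, between 5000 nM and 25000 nM.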

Compound 4, concentration for 50% growth inhibition: 28200 nM
Compound 4: the middle estimate sits 2.6-fold (0.41 log units) below what was measured; the measured number lies above the stated range.
By their numbers in this assay, from the lowest: compounds 1, 3 and 2 (each within the scatter of the next, the first and the last beyond it); then compound 4.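

In this assay, the aryl group on the saturated ring carbon responds to this exchange: 2-hydroxyphenyl in place of 3-chlorophenyl gives a 2.5-fold higher number from compound 3 to compound 4 (0.40 log units; beyond the scatter), a modest weakening of growth inhibition. The exchange alters both the substituent and its place on the phenyl ring, so this single step cannot separate the two changes. No measurement shown here accounts for the weakening.

Still open, as far as these compounds go, is how an amine or a carboxylic acid in place of the hydroxyl would compare with compound 4.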